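Swapping Phenyl for Cyclohexyl Beside the Hydroxyl

This account rests on a few compounds, and the source may have more. Where it says the series, first, only, none or still open, it means among the compounds named here.

Measured compounds:
compound 1 `O=C(NCc1cc(Cl)ccc1-n1cnnn1)[C@@H]1C[C@@H]2C[C@@H]2N1C(=O)[C@H](O)Cc1ccccn1`: 1000 nM
compound 2 `O=C(NCc1cc(Cl)ccc1-n1cnnn1)[C@@H]1C[C@@H]2C[C@@H]2N1C(=O)[C@H](O)CC1CC1`: 1700 nM
compound 3 `O=C(NCc1cc(Cl)ccc1-n1cnnn1)[C@@H]1C[C@@H]2C[C@@H]2N1C(=O)[C@H](O)c1ccccc1`: 620 nM

In a functional assay on a cell-free system (plasma, Homo sapiens), with a stated time of 3 min (on this read-out lower numbers stand for stronger inhibition and higher numbers for weaker inhibition), compound 3 gives the lowest number of the three, although the nearest step to it is only a 1.6-fold lower number from compound 1 to compound 3 (0.21 log units; within the scatter) and so cannot be read as a real difference. Compound 4 `O=C(NCc1cc(Cl)ccc1-n1cnnn1)[C@@H]1C[C@@H]2C[C@@H]2N1C(=O)[C@H](O)C1CCCCC1` differs from compound 3 by cyclohexyl in place of phenyl on a saturated chain carbon bound to a carbonyl carbon and an oxygen on a saturated carbon. For the measured compounds named here, the one step that speaks to this change is a 2.7-fold lower number from compound 2 to compound 3 (0.44 log units; beyond the scatter), where a saturated ring group gave way to phenyl and the number fell. Reversing that direction, a saturated ring entering for phenyl, suggests a modestly higher number is expected, about a 1.9-fold higher number from compound 3 to compound 4 (0.29 log units; within the scatter). Compound 4 is therefore estimated at 1200 nM, with a likely range from 500 nM to 3000 nM.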

Compound 4, half-maximal inhibitory concentration: 600 nM
Estimate against measurement, compound 4: 2.0-fold (0.30 log units) above; measured number inside the range.
By their numbers in this assay, from the lowest: compounds 4, 3, 1 and 2 (each within the scatter of the next, the first and the last beyond it).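

In this assay, a ring need not be aromatic at this position to give a number of this size: cyclohexyl in place of phenyl gives a 1.0-fold lower number from compound 3 to compound 4 (0.01 log units; within the scatter) and so cannot be told apart from phenyl. Cyclohexyl in place of cyclopropylmethyl gives a 2.8-fold lower number from compound 2 to compound 4 (0.45 log units; beyond the scatter) and is a real, if modest, difference. Cyclohexyl in place of (pyridin-2-yl)methyl gives a 1.7-fold lower number from compound 1 to compound 4 (0.22 log units; within the scatter) and cannot be read as a real difference. On these data alone, how an amine, a carboxylic acid or a longer chain would fare on this carbon remains open. No evidence here explains why phenyl and cyclohexyl match.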